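This account rests on a few compounds, and the source may have more. Where it says the series, first, only, none or still open, it means among the compounds named here.

Two compounds share one core. In a functional assay on MOLT-4 cells (Homo sapiens) for inhibition, read by sulforhodamine B assay, with a stated time of 48 h (on this read-out lower numbers stand for stronger inhibition of growth and higher numbers for weaker inhibition of growth), compound 1 `CCOC(=O)C(=Cc1c(-c2ccccc2)[nH]c2ccccc12)C(=O)OCC` gives 3900 nM, and in this assay compound 2 `CC(=O)/C(=C\c1c(-c2ccccc2)[nH]c2ccccc12)S(=O)(=O)c1ccccc1` gives 1600 nM, the lowest of the two numbers, with compound 1 the nearest and its step beyond the scatter. Compound 3 `N#C/C(=C\c1c(-c2ccccc2)[nH]c2ccccc12)S(=O)(=O)c1ccccc1` differs from compound 2 in one place: cyano in place of acetyl on a double-bonded chain carbon bound to a double-bonded chain carbon and a sulfonyl sulfur. For the measured compounds named here, no measured pair shows this change, so only a small step is expected, a 1.1-fold higher number from compound 2 to compound 3 (0.05 log units; within the scatter), in no sure direction. Compound 3 is expected to give about 1800 nM in this assay, within a range from 600 nM to 5000 nM.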

Compound 3, concentration for 50% growth inhibition: 2200 nM
For compound 3 the middle estimate is 1.2-fold (0.09 log units) below the measured one; the measured number falls inside the stated range.
By their numbers in this assay, from the lowest: compounds 2, 3 and 1 (each within the scatter of the next, the first and the last beyond it).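

For the compounds shown here, this is the first measured pair at this position. In this assay, cyano in place of acetyl on the double-bonded chain carbon bound to a double-bonded chain carbon and a sulfonyl sulfur gives a 1.4-fold higher number from compound 2 to compound 3 (0.14 log units; within the scatter), so the assay cannot tell these two groups apart here. Growth inhibition therefore survives this exchange of groups, with the sulfonyl and the shared core left unchanged. Still open, as far as these compounds go, is whether an amine, a carboxylic acid or a longer chain at this position would move the number beyond the scatter. No measurement here speaks to why acetyl and cyano read alike.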